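The compounds below may be only part of what the source reports. "The series", "measured", "known", "first", "only" and "open" are said of these compounds alone.

In an assay on HEK293 cells for displacement of a labelled ligand from B1 bradykinin receptor (Homo sapiens), read by scintillation counting (on this read-out lower numbers stand for stronger inhibition and higher numbers for weaker inhibition), compound 2 `COc1cc(C)c(S(=O)(=O)N(C)CCOCC(=O)N2CCC(C3CCN(C(C)C)CC3)CC2)c(C)c1` gives 0.4 nM, the lowest of the two numbers recorded; compound 1 `COc1cc(C)c(S(=O)(=O)N(C)CCOCC(=O)N2CCC(C3CCN(C)CC3)CC2)c(C)c1` gives 0.7 nM in this assay, and the two values lie within the scatter of each other, so neither can be ranked ahead of the other. Within the data shown here, the only step between them, a 1.8-fold lower number from compound 1 to compound 2 (0.24 log units; within the scatter), shows that exchanging the group on an amine nitrogen in a ring left the read-out within the usual spread.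

Compound 3 `COc1cc(C)c(S(=O)(=O)N(C)CCOCC(=O)N2CCC(CN3CCN(C)CC3)CC2)c(C)c1` has not yet been measured in this assay. It differs from compound 2 in one place: (4-methylpiperazin-1-yl)methyl in place of 1-isopropylpiperidin-4-yl on a saturated ring carbon. Among the measured compounds shown here, the measured step from compound 1 to compound 2 touches only the substituent on that ring nitrogen and stays within the scatter; no measured step exchanges the ring itself or adds a methylene link, so there is no direct precedent for the size of this change. Compound 3 is therefore estimated to give 2 nM, expected to fall between 0.4 nM and 10 nM. That estimate means an expected step of a 5.0-fold higher number from compound 2 to compound 3 (0.70 log units; beyond the scatter), a moderate move toward weaker binding that may still lie within the scatter.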

Compound 3, inhibition constant: 4.7 nM
Compound 3: the middle estimate sits 2.4-fold (0.37 log units) below what was measured; measured number inside the range.
By their numbers in this assay, from the lowest: compounds 2 and 1 (each within the scatter of the next); then compound 3.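

Among these compounds, the exchange of the whole group on this saturated ring carbon is the first change here to move the number in this assay beyond the scatter, with a 12-fold higher number from compound 2 to compound 3 (1.07 log units; beyond the scatter) and a 6.7-fold higher number from compound 1 to compound 3 (0.83 log units; beyond the scatter). The earlier step, which touched only the substituent on the ring nitrogen, had stayed within the scatter, so this position responds to replacing the group it carries, yet compound 3 still gives a measured 4.7 nM. Nothing given here accounts for the size of this shift.

The step from 1-methylpiperidin-4-yl to (4-methylpiperazin-1-yl)methyl changes the ring and adds a methylene link at once, so the compounds shown leave open which of the two carries the shift. A (1-methylpiperidin-4-yl)methyl group or a directly attached 4-methylpiperazin-1-yl group would separate these two changes, while an open-chain dimethylaminomethyl group would ask whether the ring is needed at all.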